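The compounds below may be only part of what the source reports. "The series", "measured", "known", "first", "only" and "open" are said of these compounds alone.

Measured in a functional assay on 143B cells (Homo sapiens) for inhibition, read by MTT assay, with a stated time of 72 h; on this read-out higher numbers stand for weaker inhibition and lower numbers for stronger inhibition:
- Compound 1 `O=C(CCC(=O)OCCCCCCSc1ccc([N+](=O)[O-])c2nonc12)Nc1ccccc1`: 3850 nM
- Compound 2 `Cc1ccc(NC(=O)CCC(=O)OCCCCCCSc2ccc([N+](=O)[O-])c3nonc23)cc1`: 3250 nM
- Compound 3 `COc1ccc(NC(=O)CCC(=O)OCCCCCCSc2ccc([N+](=O)[O-])c3nonc23)cc1`: 3060 nM

Compound 3 stands level with the other two, since a 1.3-fold lower number from compound 1 to compound 3 (0.10 log units; within the scatter) and a 1.1-fold lower number from compound 2 to compound 3 (0.03 log units; within the scatter) both stay within the scatter. The third measured step, a 1.2-fold lower number from compound 1 to compound 2 (0.07 log units; within the scatter), is equally small.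

Compound 4 `O=C(CCC(=O)OCCCCCCSc1ccc([N+](=O)[O-])c2nonc12)NCCN1CCCC1` places 2-(pyrrolidin-1-yl)ethyl in place of 4-methoxyphenyl on an amide-type nitrogen. The measured steps only swap small groups on an aromatic carbon, and none removes the aromatic ring, so they offer weak guidance here.

With no measured sign of a shift, the expected result in this assay is a 1.0-fold lower number from compound 3 to compound 4 (0.01 log units; within the scatter), which is no step beyond the scatter. For compound 4 the estimate is 3000 nM, within an expected range of 1000 nM to 9000 nM.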

Compound 4, half-maximal inhibitory concentration: 5580 nM
Beside the measured number, compound 4's estimate is 1.9-fold (0.27 log units) below it; the range from low to high includes it.
By their numbers in this assay, from the lowest: compounds 3, 2, 1 and 4 (each within the scatter of the next).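

Compound 4 shows that the aromatic ring on the amide-type nitrogen can give way to a non-aromatic group in this assay with no shift beyond the scatter: 2-(pyrrolidin-1-yl)ethyl replaces 4-methoxyphenyl (a 1.8-fold higher number from compound 3 to compound 4 (0.26 log units; within the scatter)), 4-methylphenyl (a 1.7-fold higher number from compound 2 to compound 4 (0.23 log units; within the scatter)) and phenyl (a 1.4-fold higher number from compound 1 to compound 4 (0.16 log units; within the scatter)). No supporting measurement bears on this result. Still open, as far as these compounds go, is whether the pyrrolidine ring itself matters, and whether a morpholine, a dimethylamino group, a carboxylic acid or a longer chain at this position would give a step beyond the scatter.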